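Changing the Terminal Ring on the Side Chain

The source may hold more compounds than are shown below. What is called first, only, known or untested is meant among the compounds shown, and "the series" means these compounds.

Measured compounds:
Compound 1 `COc1cc2c(Nc3nc4ccc(C(=O)Nc5c(C)cc(C)cc5C)cc4s3)ncnc2cc1OCCCN1CCC(C)CC1`: 5400 nM
Compound 2 `COc1cc2c(Nc3nc4ccc(C(=O)Nc5c(C)cccc5Cl)cc4s3)ncnc2cc1OCCCN1CCC(C)CC1`: 9700 nM

Both measured compounds were tested in a functional assay on A549 cells (Homo sapiens) for cytotoxicity, read by WST assay, with a stated time of 72 h; on this read-out higher numbers stand for weaker inhibition and lower numbers for stronger inhibition. Going by the values given here, compound 1 gives the lower of the two numbers, and its nearest neighbour is compound 2; the one measured step reads a 1.8-fold higher number from compound 1 to compound 2 (0.25 log units; within the scatter) and comes from placing 2-chloro-6-methylphenyl in place of 2,4,6-trimethylphenyl on an amide-type nitrogen.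

Compound 3 `COc1cc2c(Nc3nc4ccc(C(=O)Nc5c(C)cc(C)cc5C)cc4s3)ncnc2cc1OCCCN1CCCC1` has not yet been measured. It differs from compound 1 in one place only: pyrrolidin-1-yl in place of 4-methylpiperidin-1-yl on a saturated chain carbon, three bonds along the chain from an oxygen on an aromatic ring. Among the compounds with values here, the one measured step, the change at the amide end, does not touch this side-chain position, so no measured step bears on the change from compound 1 to compound 3. Within the data shown here, the only evidence so far is that the measured step at the other end of the shared core stayed within the scatter. Among the measured compounds shown here, with no measured step for this part of the molecule, the expectation for compound 3 is a step of no more than the scatter, no change at the digits printed from compound 1 to compound 3 (within the scatter). Compound 3 is therefore estimated at 5400 nM, with a range from 1800 nM to 16000 nM.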

Compound 3, half-maximal inhibitory concentration: 8900 nM
Beside the measured number, compound 3's estimate is 1.6-fold (0.22 log units) below it; the range from low to high includes it.
By their numbers in this assay, from the lowest: compounds 1, 3 and 2 (each within the scatter of the next).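

Going by these compounds alone, this is the first measured change at the side-chain end of the molecule. In this assay, the step reads a 1.6-fold higher number from compound 1 to compound 3 (0.22 log units; within the scatter) and so gives no sign that the terminal ring on the 3-(4-methylpiperidin-1-yl)propyl chain matters on this read-out, at least for this one swap. It also takes away two heavy atoms at once, since the six-membered ring with its methyl group gives way to the five-membered pyrrolidin-1-yl ring, and even this double alteration leaves the two numbers indistinguishable. No accompanying measurement offers an explanation for this result.

Plain piperidin-1-yl, with the six-membered ring but no methyl group, would be needed to look at ring size and the methyl group separately. A single step cannot pull the two apart. From the compounds shown here alone, it also remains open how a morpholine ring, a piperazine ring or an open-chain dimethylamino group would read at this position, whether a longer chain would alter the picture, and whether pyrrolidin-1-yl would read the same alongside the 2-chloro-6-methylphenyl amide.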